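Chain Extension on the Amide of Melatonin Receptor Ligands

The source may hold more compounds than are shown below. What is called first, only, known or untested is meant among the compounds shown, and "the series" means these compounds.

Measured compounds:
compound 1 `COc1ccc(CCCNC(C)=O)cc1`: 14000 nM
compound 2 `CCC(=O)NCCCc1ccc(OC)cc1`: 2900 nM

In an assay for binding affinity to melatonin receptor (Gallus gallus) (on this read-out higher numbers stand for weaker inhibition and lower numbers for stronger inhibition), compound 1 gives 14000 nM, and compound 2 gives 2900 nM. For the measured compounds named here, compound 2 therefore stands at the lowest of the two numbers, the only step to it being a 4.8-fold lower number from compound 1 to compound 2 (0.68 log units; beyond the scatter). Compound 3 `CCCC(=O)NCCCc1ccc(OC)cc1` carries the next change on the same chain: methyl in place of hydrogen on a saturated chain carbon, two bonds along the chain from a carbonyl carbon. Going by the values given here, the one measured step that bears on it is the earlier lengthening of the acyl chain, a 4.8-fold lower number from compound 1 to compound 2 (0.68 log units; beyond the scatter), a modest lowering beyond the scatter. The new change is the same difference moved one bond further along the chain, so a lowering of smaller size is expected in this assay for compound 3, a 1.9-fold lower number from compound 2 to compound 3 (0.29 log units; within the scatter). Compound 3 is thus estimated at 1500 nM, within a range of 500 nM to 5000 nM.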

Compound 3, inhibition constant: 860 nM
Compound 3: middle estimate off by 1.7-fold (0.24 log units), on the high side; measured number inside the range.
By their numbers in this assay, from the lowest: compound 3; then compound 2; then compound 1.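

In this assay the extra methyl two bonds along the chain from the carbonyl carbon gives a 3.4-fold lower number from compound 2 to compound 3 (0.53 log units; beyond the scatter) and so shows that the lowering seen at the carbon bound to the carbonyl carbon does not fade into the scatter one bond further out. Ethyl in place of hydrogen on the saturated chain carbon bound to the carbonyl carbon gives a 16-fold lower number from compound 1 to compound 3 (1.21 log units; beyond the scatter) as the summed step, which is large where the earlier pair had shown only a modest one. Across these three compounds the number falls with each added methyl, and none goes against this.

No measurement shown here explains this trend. As far as these compounds go, it remains open whether the lowering continues with a longer chain or holds with a branched chain, a phenyl ring or an amine at the end of the acyl chain.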